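Adding a Methoxy to the Ether Chain of Compound 1

The compounds below may be only part of what the source reports. "The series", "measured", "known", "first", "only" and "open" are said of these compounds alone.

Measured compounds in a functional assay on CHO cells for agonist activity at Free fatty acid receptor 1 (Homo sapiens), read by FLIPR and calcium flux; on this read-out lower numbers stand for an effect already at smaller amounts and higher numbers for an effect only at larger amounts of compound:
Compound 1 `CCOc1cc(C)c(-c2cccc(COc3ccc(OCC(=O)O)c(F)c3)c2)c(C)c1` gives 65.9 nM.
Compound 2 `Cc1cc(OCCCS(C)(=O)=O)ccc1-c1cccc(COc2ccc(OCC(=O)O)c(F)c2)c1` gives 43.6 nM.
Compound 3 `CCCOc1cc(C)c(-c2cccc(COc3ccc(OCC(=O)O)c(F)c3)c2)c(C)c1` gives 106 nM.

Among these three numbers compound 1 has the second highest; compound 2 is nearest and compound 3 furthest, and both gaps are within the scatter. Compound 4 `COCCOc1cc(C)c(-c2cccc(COc3ccc(OCC(=O)O)c(F)c3)c2)c(C)c1` is not yet measured. It differs from compound 1 by methoxy in place of hydrogen on a saturated chain carbon, two bonds along the chain from an oxygen on an aromatic ring. Within the data shown here, only one measured step touches the same place: the step of a 1.6-fold higher number from compound 1 to compound 3 (0.21 log units; within the scatter), where a methyl rather than a methoxy enters, and it stayed within the scatter. The change to compound 4 is therefore expected to give no step beyond the scatter, a 1.1-fold higher number from compound 1 to compound 4 (0.06 log units; within the scatter). Compound 4 is estimated at 75 nM, within a range from 35 nM to 160 nM.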

Compound 4, half-maximal effective concentration: 104 nM
Compound 4: the middle estimate sits 1.4-fold (0.14 log units) below what was measured, and the stated range covers the measured number.
By their numbers in this assay, from the lowest: compounds 2, 1, 4 and 3 (each within the scatter of the next, the first and the last beyond it).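

At this chain carbon, methoxy in place of hydrogen gives a 1.6-fold higher number from compound 1 to compound 4 (0.20 log units; within the scatter), and methoxy in place of methyl gives a 1.0-fold lower number from compound 3 to compound 4 (0.01 log units; within the scatter). The position has now taken both a methyl and a methoxy without a step beyond the scatter, so the swap between these two groups also leaves the number effectively unchanged. Nothing available gives a reason for this result. Still open, going by these compounds, is whether an amine or a carboxylic acid placed here would also stay within the scatter. On these data alone, a longer chain or a hydroxyl in place of the methoxy is equally open.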